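Cyclobutyl Ester on a Thiophene Analogue: Expected Adenosine Binding

The compounds below may be only part of what the source reports. "The series", "measured", "known", "first", "only" and "open" are said of these compounds alone.

Compound 1 `CCC(C)OC(=O)C1=C(C)NC(=O)NC1c1ccoc1`, compound 2 `CC1=C(C(=O)OC2CCC2)C(c2ccoc2)NC(=O)N1` and compound 3 `CCC(C)OC(=O)C1=C(C)NC(=O)NC1c1ccsc1` share one core, a six-membered ring bearing an ester and an aromatic five-membered ring. In an assay on membranes from HeLa cells for displacement of a labelled ligand from adenosine receptor A3 (Homo sapiens), read by scintillation counting, with a stated time of 180 min, tested at 1 uM (on this read-out lower numbers stand for less inhibition and higher numbers for more inhibition at the one concentration tested (going by the name of the read-out)), compound 1 gives 11%, compound 2 gives 1% and compound 3 gives 7%. Between compound 1 and compound 2 the change is cyclobutyl in place of sec-butyl on an oxygen next to a carbonyl group, and on this read-out it gives a number 10 percentage points lower from compound 1 to compound 2 (within the scatter). Exchanging the aromatic ring, thiophen-3-yl in place of furan-3-yl on a saturated ring carbon, gives a number 4 percentage points lower from compound 1 to compound 3 (within the scatter). Compound 4 `CC1=C(C(=O)OC2CCC2)C(c2ccsc2)NC(=O)N1` has not been measured. Relative to compound 3 it carries cyclobutyl in place of sec-butyl on an oxygen next to a carbonyl group, the same change as that from compound 1 to compound 2, at the same place. The two cores differ in thiophen-3-yl in place of furan-3-yl on a saturated ring carbon. Because the earlier step gave a number 10 percentage points lower from compound 1 to compound 2 (within the scatter), the step to compound 4 is expected to be similar, a number 5 percentage points lower from compound 3 to compound 4 (within the scatter), which would leave compound 4 with very little inhibition. Compound 4 is therefore estimated at 2%, with a range from -8% to 12%.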

Compound 4, a percentage reported as inhibition, at one concentration (the size of the read-out at that concentration, not a potency): 3%
Beside the measured number, compound 4's estimate is 1 percentage points below it, and the stated range covers the measured number.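

In this assay, cyclobutyl in place of sec-butyl on the thiophen-3-yl core gives a number 4 percentage points lower from compound 3 to compound 4 (within the scatter), and this agrees with the same change on the furan-3-yl core: the same change on two cores in this assay, a number 10 percentage points lower (within the scatter) from compound 1 to compound 2 and a number 4 percentage points lower (within the scatter) from compound 3 to compound 4, 6 percentage points apart, within the scatter of two such steps. The ring exchange, thiophen-3-yl in place of furan-3-yl, gives a number 2 percentage points higher from compound 2 to compound 4 (within the scatter) with the cyclobutyl ester, and it too agrees with the earlier step: the same change on two cores in this assay, a number 4 percentage points lower (within the scatter) from compound 1 to compound 3 and a number 2 percentage points higher (within the scatter) from compound 2 to compound 4, 6 percentage points apart, within the scatter of two such steps. Within the data shown here, since every one of these steps lies within the usual scatter, the agreement shows only that neither change has a detectable effect on either core at the one concentration tested; it does not show that either change has a real effect that carries from one core to another.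

The compounds shown leave open what a larger group on the ester oxygen, such as benzyl, or a phenyl ring in place of the five-membered aromatic ring would give in this assay. They also leave open whether an amide in place of the ester would produce a step beyond the scatter, which a real test of carry-over between cores would need.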